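Chalcone-Type Quinolines: Heteroaryl Ketone Replacing Nitrophenyl

A few compounds are considered here, and "the series" means these few. Any claim that something is new, unique, unknown or untested is made for them only; others in the source may bear on it.

This study concerns three measured compounds that share one core and differ only in the aryl group attached to the carbonyl carbon. Compound 1 `COc1ccc(-c2cc3ccccc3nc2/C=C/C(=O)c2ccccc2)cc1` gives 860 nM in a functional assay on MDA-MB-231 cells (Homo sapiens) for antiproliferative activity, read by XTT assay, with a stated time of 72 h; a higher number here means a weaker inhibitor, a lower number a stronger inhibitor. Compound 2 `COc1ccc(-c2cc3ccccc3nc2/C=C/C(=O)c2ccc(OC)cc2OC)cc1` gives 3210 nM in this assay, and compound 3 `COc1ccc(-c2cc3ccccc3nc2/C=C/C(=O)c2ccc([N+](=O)[O-])cc2)cc1` gives 840 nM. Among these three numbers compound 3 holds the lowest, with compound 1 within the scatter of it and compound 2 the furthest away, as the step of a 3.8-fold lower number from compound 2 to compound 3 (0.58 log units; beyond the scatter) shows. The step of a 3.7-fold higher number from compound 1 to compound 2 (0.57 log units; beyond the scatter) was a modest weakening, whereas a 1.0-fold lower number from compound 1 to compound 3 (0.01 log units; within the scatter) stayed within the scatter.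

Compound 4 `COc1ccc(-c2cc3ccccc3nc2/C=C/C(=O)c2cnc(N)nc2C)cc1` differs from compound 3 by the change (2-amino-4-methylpyrimidin-5-yl in place of 4-nitrophenyl on a carbonyl carbon). Going by the values given here, none of the measured steps probes a heteroaryl ring here; the steps from compound 1 show that a substituted phenyl can weaken the number modestly or leave it unchanged. A larger change than any measured one, with a ring of a different kind, is expected to cost somewhat, so the estimated step is a 1.8-fold higher number from compound 3 to compound 4 (0.25 log units; within the scatter). For compound 4 the estimated value in this assay is 1500 nM, with a range from 500 nM to 5000 nM.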

Compound 4, half-maximal inhibitory concentration: > 10000 nM
Compound 4: no number, only a limit; the forecaster's own chance of this, stated with the estimate: 5%; middle value at least 6.6-fold (0.82 log units) away from the limit.
By their numbers in this assay, from the lowest: compounds 3 and 1 (each within the scatter of the next); then compound 2. At a limit, above all of these: compound 4.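

Compound 4 carries a limit of the assay and not a number: the limit of > 10000 nM in this assay, at which 1 of the 4 values shown sits. Going by these compounds alone, on the carbonyl carbon, the earlier aryl changes left the number in place or moved it modestly, whereas 2-amino-4-methylpyrimidin-5-yl in place of a carbon-only aromatic ring brings the first large steps, an at least 11-fold higher number from compound 3 to compound 4 (1.07 log units; beyond the scatter) and an at least 11-fold higher number from compound 1 to compound 4 (1.06 log units; beyond the scatter). Even compound 2, which held the highest number until now, lies clearly under this limit, with an at least 3.1-fold higher number from compound 2 to compound 4 (0.49 log units; beyond the scatter), so this position tolerates the phenyl and 4-nitrophenyl groups far better than this heteroaryl group.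

Going by these compounds, how far compound 4 lies past the limit stays unknown, so the true size of all three steps is open. The change also brings in the ring nitrogens, the amine and the methyl group at once, and the compounds shown cannot separate them: an unsubstituted pyrimidin-5-yl group or a 4-aminophenyl group on the same carbonyl carbon would be needed to tell which part carries the loss.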